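A few compounds are considered here, and "the series" means these few. Any claim that something is new, unique, unknown or untested is made for them only; others in the source may bear on it.

Of the compounds shown here, three of a shared core have been measured in an assay on HEK293 cells for displacement of a labelled ligand from Melanocortin receptor 4 (Homo sapiens); on this read-out higher numbers stand for weaker inhibition and lower numbers for stronger inhibition. Compound 1 `CC[C@H](C)C(N)c1cc(C(F)(F)F)ccc1N1CCN(C(=O)CCc2ccc(Cl)cc2Cl)CC1` gives 75 nM, and compound 2 `CCC(C)C(N)c1cc(C(F)(F)F)ccc1N1CCN(C(=O)CCc2ccc(Cl)cc2Cl)CC1` gives 160 nM; these two are the same molecule drawn with and without a defined configuration at one carbon, and the gap a 2.1-fold higher number from compound 1 to compound 2 (0.33 log units; beyond the scatter) is read in the light of the fact that one of compounds 1 and 2 is drawn with a defined configuration and the other without, at the place where they differ. Compound 3 `COCCN[C@@H](CC(C)C)c1cc(C(F)(F)F)ccc1N1CCN(C(=O)CCc2ccc(Cl)cc2Cl)CC1` gives 620 nM, the highest of the three numbers, so the weakest binder among them.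

Compound 4 `CC(C)C[C@H](NC(=O)CCN)c1cc(C(F)(F)F)ccc1N1CCN(C(=O)CCc2ccc(Cl)cc2Cl)CC1` takes the step ((2-aminoethyl)carbonyl in place of 2-methoxyethyl on an amine nitrogen), in which the group on the amine nitrogen, whose other neighbour is a saturated chain carbon, becomes part of an amide. For the measured compounds named here, the steps that bear on this place are an 8.3-fold higher number from compound 1 to compound 3 (0.92 log units; beyond the scatter) and a 3.9-fold higher number from compound 2 to compound 3 (0.59 log units; beyond the scatter): each time the amine carried a larger substituent instead of bare amino, the number rose. Compound 4 keeps a substituent of similar length there, so a modest further rise or no change beyond the scatter is expected, with a step of a 1.6-fold higher number from compound 3 to compound 4 (0.21 log units; within the scatter). Compound 4 is therefore estimated at 1000 nM, within a range of 300 nM to 3500 nM in this assay.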

Compound 4, inhibition constant: 25 nM
For compound 4 the middle estimate is 40-fold (1.60 log units) above the measured one, and the stated range ends above it.
By their numbers in this assay, from the lowest: compound 4; then compound 1; then compound 2; then compound 3.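

In this assay, for the compounds shown here, the earlier compounds showed only a rising number as the amine nitrogen gained a substituent, but a 25-fold lower number from compound 3 to compound 4 (1.39 log units; beyond the scatter) shows that the identity of the group on that nitrogen matters, not merely whether one is there. Turning this amine into an amide by swapping 2-methoxyethyl for (2-aminoethyl)carbonyl gives compound 4 the lowest number of the four, so a substituent at this place need not weaken binding. Compound 4 also improves on the compounds with a bare amino group, with a 6.4-fold lower number from compound 2 to compound 4 (0.81 log units; beyond the scatter) and a 3.0-fold lower number from compound 1 to compound 4 (0.48 log units; beyond the scatter), although in both of these steps the 2-methylbutyl carbon chain also becomes a 3-methylbutyl chain, so they are not clean readings of the nitrogen substituent alone.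

The information at hand gives no explanation for the size of the step from compound 3 to compound 4. On these data alone, it also remains open whether the gain depends on the carbonyl, the terminal amine or both, a question that a simple acetyl group or a 2-aminoethyl group on the same nitrogen could help to answer.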